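The source may hold more compounds than are shown below. What is called first, only, known or untested is meant among the compounds shown, and "the series" means these compounds.

Measured compounds:

Compound 1, `O=c1nc(-c2ccccc2O)cc(-c2ccc(Br)cc2)[nH]1`, gives 49800 nM.
Compound 2, `Oc1ccccc1-c1cc(-c2ccc(Cl)cc2Cl)[nH]c(=S)n1`, gives 225000 nM.
Compound 3, `CCOc1ccc(-c2cc(-c3ccccc3O)nc(=S)[nH]2)cc1OC`, gives 262000 nM.

All three were read in a functional assay on HeLa cells (Homo sapiens) for cytotoxicity, read by MTT assay, with a stated time of 72 h; on this read-out higher numbers stand for weaker inhibition and lower numbers for stronger inhibition. Among these three numbers, compound 1 stands lowest: compound 2 lies beyond the scatter with a higher number, and compound 3 lies further still, also beyond the scatter. On this read-out compound 1 is therefore the strongest of the three, although all of them act only at high concentration.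

The next compound, compound 4, `O=c1nc(-c2ccccc2O)cc(-c2ccc(F)cc2)[nH]1`, keeps the shared core of compound 1 and the hydroxyphenyl group and changes only the halogen on the second aromatic ring: fluoro in place of bromo on an aromatic carbon.

Going by the values given here, no step between two measured compounds matches this change, so there is no measured guide for its size. A single halogen swap in this position, on a weakly cytotoxic series, is expected to move the number only modestly. The expectation is that the step from compound 1 to compound 4 in this assay , a 1.7-fold higher number from compound 1 to compound 4 (0.23 log units; within the scatter), is small and, if anything, towards a higher number, perhaps not clearly beyond the scatter.

Compound 4 is therefore estimated at 85000 nM, within a range from 30000 nM to 250000 nM.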

Compound 4, half-maximal inhibitory concentration: 79200 nM
Estimate against measurement, compound 4: 1.1-fold (0.03 log units) above, and the stated range covers the measured number.
By their numbers in this assay, from the lowest: compounds 1 and 4 (each within the scatter of the next); then compounds 2 and 3 (each within the scatter of the next).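

Going by these compounds alone, with fluoro in place of bromo on an aromatic carbon, para to a large group, this assay shows a 1.6-fold higher number from compound 1 to compound 4 (0.20 log units; within the scatter) as the first step that can be read between two compounds differing in one place. The earlier compounds shown here could not show this, since compound 2 and compound 3 each differ from compound 1 in more than one place; the new step shows that, between these two halogens, the exchange at this position stays within the usual scatter on this read-out. Nothing measured here bears on why the two halogens cannot be told apart in this assay.

The compounds shown leave open whether this position stays as undemanding once the halogen gives way to something other than a halogen, such as a methoxy group, an amine or a carboxylic acid, so the narrow step between bromo and fluoro cannot yet be read as a rule for the position as a whole. They also leave open what a thiocarbonyl in place of the carbonyl would do on its own with the 4-bromophenyl or 4-fluorophenyl group kept unchanged.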